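Sulfone to sulfonamide at the shared core

The compounds below may be only part of what the source reports. "The series", "measured", "known", "first", "only" and "open" are said of these compounds alone.

compound 1 `Cn1c(=O)c(S(=O)(=O)c2ccc(F)cc2[N+](=O)[O-])cc2cnc(Nc3ccc4[nH]ccc4c3)nc21`: 1500 nM
compound 2 `Cc1ccc(S(=O)(=O)c2cc3cnc(Nc4ccc5cc[nH]c5c4)nc3n(C)c2=O)cc1`: 15000 nM
compound 3 `Cn1c(=O)c(S(=O)(=O)c2ccc(F)cc2)cc2cnc(Nc3ccc4[nH]ncc4c3)nc21`: 5000 nM

Of the compounds shown here, three have been measured in a functional assay on DU-145 cells (Homo sapiens) for inhibition, read by trypan blue exclusion, with a stated time of 72 h; a higher number here means a weaker inhibitor, a lower number a stronger inhibitor. Among them compound 1 gives the lowest number. Its nearest neighbour on the numbers is compound 3, whose higher value lies beyond the usual scatter of this assay, and the furthest is compound 2, whose value lies still further beyond it. For the measured compounds named here, no pair of these measured compounds differs in a single place, so none of the gaps between them can be read as the effect of one change alone.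

The next compound, compound 4 `Cn1c(=O)c(S(=O)(=O)Nc2ccc(F)cc2)cc2cnc(Nc3ccc4[nH]ccc4c3)nc21`, has not been measured yet. It differs from compound 1 in one place only: (4-fluorophenyl)amino in place of 4-fluoro-2-nitrophenyl on a sulfonyl sulfur. Going by the values given here, the measured set holds no step that isolates such a change; compound 3 carries a 4-fluorophenyl on its sulfonyl sulfur but also a different ring on the other side of the core, so its value is only loosely informative.

On that basis a moderate step toward a higher number, beyond the scatter, is expected: a 2.3-fold higher number from compound 1 to compound 4 (0.37 log units; beyond the scatter). In this assay compound 4 is estimated at 3500 nM, with a range from 900 nM to 14000 nM.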

Compound 4, half-maximal inhibitory concentration: 5000 nM
Compound 4: the middle estimate sits 1.4-fold (0.15 log units) below what was measured; measured number inside the range.
By their numbers in this assay, from the lowest: compound 1; then compounds 3 and 4 (each within the scatter of the next); then compound 2.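

In this assay, for the compounds shown here, the swap of 4-fluoro-2-nitrophenyl for (4-fluorophenyl)amino on the sulfonyl sulfur provides the first change in this set that can be read on its own, and it gives a 3.3-fold higher number from compound 1 to compound 4 (0.52 log units; beyond the scatter) as a modest loss of inhibition at this position, not an abolition of it. The step still bundles two alterations, since the nitro group leaves and an amino link enters between the sulfonyl sulfur and the aromatic ring, and the pair of compound 1 and compound 4 cannot assign the step to either alteration. No measurement bears on why this replacement shifts the number.

The compounds shown do not separate the loss of the nitro group from the arrival of the amino link, which a 4-fluorophenyl group or a 2-nitroanilino group on the same sulfur and the same shared core would address directly. They also leave open whether the sulfonyl sulfur accepts a saturated amine such as morpholine or piperidine in place of the (4-fluorophenyl)amino group.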